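From Nitro to Fluoro in a Cell Tolerance Test

This account rests on a few compounds, and the source may have more. Where it says the series, first, only, none or still open, it means among the compounds named here.

In an ADME assay on Vero cells (Chlorocebus sabaeus) for inhibition (a lower number here means that less compound is tolerated, a higher number that more compound is tolerated), compound 1 `O=C1/C(=C/c2c(Cl)cccc2Cl)CCC/C1=C\c1c(Cl)cccc1Cl` gives 574000 nM, compound 2 `COc1ccc(/C=C2\CCC/C(=C\c3cccc(OC)c3OC)C2=O)cc1` gives 401000 nM, and compound 3 `COc1ccc(/C=C2\CCC/C(=C\c3ccc([N+](=O)[O-])cc3)C2=O)cc1` gives 435000 nM. Compound 3 thus stands level with the other two, its gaps to both lying within the usual scatter of repeated measurements. Compound 4 `COc1ccc(/C=C2\CCC/C(=C\c3ccc(F)cc3)C2=O)cc1` carries fluoro in place of nitro on an aromatic carbon, para to a large group (fluoro in place of nitro on an aromatic carbon). Among the measured compounds shown here, no measured pair isolates a single change, so the size of this step cannot be read directly. The expectation therefore rests on compound 3 at 435000 nM and on the close agreement among the three measured compounds. The estimated step of a 1.0-fold higher number from compound 3 to compound 4 (0.01 log units; within the scatter) stays within the scatter. For compound 4, the expected value is 450000 nM, with an estimated range of 250000 nM to 800000 nM.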

Compound 4, half-maximal cytotoxic concentration: 378000 nM
Estimate against measurement, compound 4: 1.2-fold (0.08 log units) above; low and high end bracket the measured number.
By their numbers in this assay, from the lowest: compounds 4, 2, 3 and 1 (each within the scatter of the next).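

Fluoro in place of nitro gives a 1.2-fold lower number from compound 3 to compound 4 (0.06 log units; within the scatter) in this assay and is the first measured step that isolates a single change at this position. Nitro, with 3 heavy atoms and 2 hydrogen-bond acceptors, gives way here to fluoro, with 1 heavy atom and no hydrogen-bond acceptors, yet the tolerated concentration does not move beyond the scatter.

Going by these compounds, whether an amine or a carboxylic acid at this position would also stay within the scatter remains open. No measurement at hand offers an explanation for this result.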